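The source may hold more compounds than are shown below. What is called first, only, known or untested is meant among the compounds shown, and "the series" means these compounds.

Measured compounds:
- Compound 1 `CN(C)CCn1cnnc1-c1cc(Oc2ccc(NC(=O)N/N=C/c3ccc(Cl)cc3Cl)cc2F)ccn1` gives 2330 nM in a functional assay on U-87MG ATCC cells (Homo sapiens) for cytotoxicity, read by MTT assay, with a stated time of 72 h; a higher number here means a weaker inhibitor, a lower number a stronger inhibitor.
- Compound 2 `CN(C)CCn1cnnc1-c1cc(Oc2ccc(NC(=O)N/N=C/c3cc(C(C)(C)C)cc(C(C)(C)C)c3O)cc2F)ccn1` gives 520 nM in this assay.
- Compound 3 `COc1ccc(OC)c(/C=N/NC(=O)Nc2ccc(Oc3ccnc(-c4nncn4CCN(C)C)c3)c(F)c2)c1` gives 6400 nM in this assay.

All three share one core and differ only in the aromatic ring attached to the carbon that is double-bonded to nitrogen. Compound 3 has the highest number of the three in this assay, so it is the weakest inhibitor of this small set: compound 1 comes nearest, and compound 2 lies furthest away with a much lower number.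

Compound 4 `CN(C)CCn1cnnc1-c1cc(Oc2ccc(NC(=O)N/N=C/c3ccccc3)cc2F)ccn1` is the next compound, and it differs from compound 3 in one place: phenyl in place of 2,5-dimethoxyphenyl on a carbon with a double bond to nitrogen. Within the data shown here, only one measured step bears on this change, the one that swapped one pattern of substituents on this ring for another: a 2.7-fold higher number from compound 1 to compound 3 (0.44 log units; beyond the scatter). Among the measured compounds shown here, no measured step removes all substituents from this ring, so the direction is not settled by the data; the change is expected to be modest, with the number of compound 4 expected to drop back toward that of compound 1, as a 1.6-fold lower number from compound 3 to compound 4 (0.20 log units; within the scatter). Compound 4 is therefore estimated at 4000 nM, with a range from 1300 nM to 12000 nM.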

Compound 4, half-maximal inhibitory concentration: 2250 nM
The estimate for compound 4 lay 1.8-fold (0.25 log units) above the measured number, within the range that was stated.
By their numbers in this assay, from the lowest: compound 2; then compounds 4 and 1 (each within the scatter of the next); then compound 3.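

Phenyl on the carbon with a double bond to nitrogen gives the unsubstituted reference ring that the earlier compounds lacked: in this assay, replacing 2,5-dimethoxyphenyl with phenyl gives a 2.8-fold lower number from compound 3 to compound 4 (0.45 log units; beyond the scatter). Replacing 2,4-dichlorophenyl with phenyl gives a 1.0-fold lower number from compound 1 to compound 4 (0.02 log units; within the scatter), so at this position the assay does not separate the bare ring from the dichlorinated one, while the dimethoxylated ring is distinguishable from it. Nothing measured here explains why these two substituted rings behave differently.

The compounds shown leave open whether a single methoxy group on this ring would be enough to raise the number, or whether both are needed. They also leave open how this ring would respond to an amine, a carboxylic acid or a longer alkyl chain.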